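From Hydroxy to Nitro at the Assay Limit

The source may hold more compounds than are shown below. What is called first, only, known or untested is meant among the compounds shown, and "the series" means these compounds.

In a toxicity assay on THP-1 cells (Homo sapiens) for inhibition (on this read-out higher numbers stand for lower toxicity in this test and lower numbers for higher toxicity in this test), compound 1 `COc1ccc(-c2cnc(NC(=O)c3ccc(O)cc3)n2C)cc1` gives > 100000 nM, which is a limit of the assay and not a number. Compound 2 `COc1ccc(-c2cnc(NC(=O)c3ccccc3C)n2C)cc1` also gives only a limit, > 100000 nM. Compound 3 `COc1ccc(-c2cnc(NC(=O)c3cccc(F)c3)n2C)cc1` likewise gives only a limit, > 100000 nM. The picture so far therefore rests on (the limit of > 100000 nM in this assay, at which 3 of the 3 values shown sit).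

Compound 4 `COc1ccc(-c2cnc(NC(=O)c3ccc([N+](=O)[O-])cc3)n2C)cc1` keeps the core of compound 1 and carries nitro in place of hydroxy on an aromatic carbon, para to a large group: nitro in place of hydroxy on an aromatic carbon.

For the measured compounds named here, no measurement yet covers this exchange directly. The nearest evidence comes from changes to the group on the carbonyl carbon, namely a step that the two limits leave unreadable from compound 1 to compound 2, a step that the two limits leave unreadable from compound 1 to compound 3 and a step that the two limits leave unreadable from compound 2 to compound 3. None of these three steps has a readable size, so they set no number for the new step. Going by the values given here, they show only that all three compounds share the same limit in this assay. No step beyond the scatter can be predicted with confidence, and compound 4 is most likely to remain at the limit. Any readable shift is expected toward lower numbers, because compound 1 holds the limit > 100000 nM.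

The expected result is a number no higher from compound 1 to compound 4 (the limit leaves the size open). Compound 4 is estimated at about 100000 nM, with an expected range of 40000 nM to 200000 nM.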

Compound 4, half-maximal cytotoxic concentration: > 100000 nM
Compound 4: a limit, no number (the forecaster's own chance of this, stated with the estimate: 75%); the middle value sits exactly at the limit.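

In this assay compound 4 gives > 100000 nM, which is a limit of the assay and not a number. Compound 1 also stands at a limit, so the step between compound 1 and compound 4 cannot be read. The compounds shown leave open whether any exchange on the carbonyl carbon changes the read-out at all, since none gives a number: the limit of > 100000 nM in this assay, at which 4 of the 4 values shown sit.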